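The source may hold more compounds than are shown below. What is called first, only, known or untested is meant among the compounds shown, and "the series" means these compounds.

- compound 1 `COc1ccc(-n2c(SC)nnc2-c2cc(OC)c(OC)c(OC)c2)cc1` gives > 60000 nM as a limit
- compound 2 `COc1ccc(-n2c(SCc3ccccc3)nnc2-c2cc(OC)c(OC)c(OC)c2)cc1` gives 34100 nM as a number
- compound 3 `COc1cc(-c2nnc(SC)n2-c2ccc(N(C)C)cc2)cc(OC)c1OC` gives > 60000 nM as a limit

In a functional assay on PC-3 cells (Homo sapiens) for inhibition, read by MTT assay, with a stated time of 48 h (on this read-out higher numbers stand for weaker inhibition and lower numbers for stronger inhibition), compound 3 gives > 60000 nM as a limit, so it has no exact place on the scale. Compound 1 sits at the same limit. Compound 4 `COc1cc(-c2nnc(SCc3ccccc3)n2-c2ccc(N(C)C)cc2)cc(OC)c1OC` differs from compound 3 by one change, phenyl in place of hydrogen on a saturated chain carbon bound to a sulfur (methylsulfanyl to benzylsulfanyl). The same change has been measured once, as an at least 1.7-fold lower number from compound 1 to compound 2 (0.24 log units; that floor lies within the scatter) and it leads to compound 2 with 34100 nM as a real number. The other measured step, a step that the two limits leave unreadable from compound 1 to compound 3 has no readable size. A modest fall in the number is therefore expected, possibly none beyond the scatter. The estimate amounts to an expected at least 1.7-fold lower number from compound 3 to compound 4 (0.23 log units; that floor lies within the scatter) and no more. Compound 4 is expected near 35000 nM with an estimated range of 14000 nM to 60000 nM for its value.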

Compound 4, half-maximal inhibitory concentration: 55800 nM
For compound 4 the middle estimate is 1.6-fold (0.20 log units) below the measured one; low and high end bracket the measured number.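

On the core of compound 3, benzylsulfanyl in place of methylsulfanyl yields a real number in this assay, yet the step remains only a floor: an at least 1.0-fold lower number from compound 3 to compound 4 (0.03 log units; that floor lies within the scatter). The change can now be compared on two cores, and neither reading is firm: the same change on two cores in this assay, an at least 1.7-fold lower number (0.24 log units; that floor lies within the scatter) from compound 1 to compound 2 and an at least 1.0-fold lower number (0.03 log units; that floor lies within the scatter) from compound 3 to compound 4; the limit leaves it open whether they differ. Among these compounds, with benzylsulfanyl held fixed, dimethylamino in place of methoxy becomes readable for the first time, and the step stays small: a 1.6-fold higher number from compound 2 to compound 4 (0.21 log units; within the scatter).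

From the compounds shown here alone, whether the change to benzylsulfanyl truly lowers the number on either core remains open. Also open, going by these compounds, is how an amine or a carboxylic acid in place of the phenyl would read.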